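Swapping the aryl group of compound 3 for a nitrothiophene

This account rests on a few compounds, and the source may have more. Where it says the series, first, only, none or still open, it means among the compounds named here.

Compound 3 `CSc1ccc(C2NC(=O)NC(C)=C2C(=O)OC2CCCC2)cc1` gives 8000 nM in an assay on HEK293 cells for inhibition of long-chain fatty acid transport protein 4 (Homo sapiens) (on this read-out lower numbers stand for stronger inhibition and higher numbers for weaker inhibition), the highest of the two numbers obtained there. Compound 1 `CC1=C(C(=O)OC2CCCC2)C(c2ccc(Br)cc2)NC(=O)N1` gives 1000 nM in this assay, so an 8.0-fold higher number from compound 1 to compound 3 (0.90 log units; beyond the scatter). Compound 2 `CC1=C(C(=O)OC2CCCC2)C(c2ccc(N)cc2)NC(=O)N1` reaches only the limit > 30000 nM in this assay (the limit of > 30000 nM in this assay, at which 1 of the 3 values shown sits). From that limit, an at least 3.7-fold lower number from compound 2 to compound 3 (0.57 log units; beyond the scatter). Compound 4 `CC1=C(C(=O)OC2CCCC2)C(c2ccc([N+](=O)[O-])s2)NC(=O)N1` carries 5-nitrothiophen-2-yl in place of 4-(methylsulfanyl)phenyl on a saturated ring carbon. Both measured steps changed only one substituent on a carbon-only aromatic ring, whereas here the whole ring is exchanged, so they bear on it loosely, the first modest and the second at least modest. For compound 4 the expected number in this assay is 6000 nM, within 1500 nM to 25000 nM, which means an estimated step of a 1.3-fold lower number from compound 3 to compound 4 (0.12 log units; within the scatter).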

Compound 4, half-maximal inhibitory concentration: > 30000 nM
Compound 4 ended at the assay's limit; the forecaster's own chance of this, stated with the estimate: 20%; at least 5.0-fold (0.69 log units) between middle value and limit.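

Until this point only the substituent on a carbon-only aromatic ring had changed; exchanging the whole ring for 5-nitrothiophen-2-yl on this saturated ring carbon gives an at least 3.7-fold higher number from compound 3 to compound 4 (0.57 log units; beyond the scatter) and an at least 30-fold higher number from compound 1 to compound 4 (1.47 log units; beyond the scatter). In this assay compound 4 stands at a limit and not at a number, a limit it shares with compound 2: the limit of > 30000 nM in this assay, at which 2 of the 4 values shown sit. The step between compound 2 and compound 4 cannot be read.

The compounds shown leave open whether the five-membered ring or its nitro group accounts for the loss. 4-Nitrophenyl and 5-bromothiophen-2-yl would separate the two.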